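A few compounds are considered here, and "the series" means these few. Any claim that something is new, unique, unknown or untested is made for them only; others in the source may bear on it.

Of the compounds shown here, two have been measured in a functional assay on HEK293 cells for agonist activity at D(4) dopamine receptor (Homo sapiens), read by FLIPR; on this read-out higher numbers stand for an effect only at larger amounts of compound and lower numbers for an effect already at smaller amounts. Compound 1, with the structure `O=C(NCN1CCC(c2cccc[n+]2[O-])CC1)c1cnccc1Cl`, gives 1290 nM in this assay. Compound 2, with the structure `O=C(CN1CCC(c2cccc[n+]2[O-])CC1)NC1CCCCC1`, gives 294 nM in this assay, the lower of the two numbers. The gap to compound 1 lies beyond the scatter of repeated measurements.

Compound 3, with the structure `Cc1ccc(Cl)cc1NC(=O)CN1CCC(c2cccc[n+]2[O-])CC1`, has not yet been measured. It is built from compound 2 by one change: 5-chloro-2-methylphenyl in place of cyclohexyl on an amide-type nitrogen. Within the data shown here, no pair of measured compounds shows the effect of this kind of exchange, so no measured step can guide the expectation directly.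

The expected step in this assay from compound 2 to compound 3 is a 1.2-fold lower number from compound 2 to compound 3 (0.07 log units; within the scatter), close to the scatter and with no confident direction. Compound 3 is estimated to give 250 nM in this assay, within a range from 60 nM to 1000 nM.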

Compound 3, half-maximal effective concentration: 126 nM
Compound 3: middle estimate off by 2.0-fold (0.30 log units), on the high side, and the stated range covers the measured number.
By their numbers in this assay, from the lowest: compound 3; then compound 2; then compound 1.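

Placing 5-chloro-2-methylphenyl instead of cyclohexyl on the amide-type nitrogen gives, in this assay, a 2.3-fold lower number from compound 2 to compound 3 (0.37 log units; beyond the scatter). This first readable step at this place shows that the number responds to the group on this nitrogen, and that an aromatic carbon ring with two added groups can stand here without losing activity. Nothing available explains the modest gain.

The compounds shown leave open whether the gain belongs to the aromatic ring itself, to the chlorine or to the methyl, since all three enter together. Plain phenyl on the same nitrogen would begin to separate these, while benzyl or pyridyl there would show how far the trend extends beyond this single exchange.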